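Amino on the pyrrolidine ring: a small step from compound 2

The source may hold more compounds than are shown below. What is called first, only, known or untested is meant among the compounds shown, and "the series" means these compounds.

Compound 2 `Clc1ccc(Oc2ccc3nc(-c4ccc(OCCCN5CCCC5)cc4)oc3c2)cc1` carries the shared core of this set with a chain that ends in pyrrolidin-1-yl. In an assay on isolated protein for inhibition of advanced glycosylation end product-specific receptor (Homo sapiens), read by FRET, with stated times of 30 min and 1 h, tested at 4 uM (on this read-out lower numbers stand for less inhibition and higher numbers for more inhibition at the one concentration tested (going by the name of the read-out)), compound 2 is reported as "not active" (no number reported), and no single number stands behind that word, so its place on the scale is only known to be at the weak end. The related compound 1 `CCN1CCC(COc2ccc(-c3nc4ccc(Oc5ccc(Cl)cc5)cc4o3)cc2)CC1`, which bears a different amine on its chain, gives 2.1% in this assay, a value that sits at the bottom of the range as well. The two results therefore point the same way: neither compound shows inhibition worth speaking of at the one concentration tested.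

Compound 3 `N[C@H]1CCN(CCCOc2ccc(-c3nc4ccc(Oc5ccc(Cl)cc5)cc4o3)cc2)C1` differs from compound 2 in one place, (amino in place of hydrogen on a saturated ring carbon). Within the data shown here, no measured pair in this set shows what such a change does in this assay. With compound 1 and compound 2 both at the floor, the step to compound 3 is expected to stay within the scatter, with no direction that could be told apart from noise. Compound 3 is thus estimated to give 5% in this assay, within a range from -5% to 20%.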

Compound 3, a percentage reported as inhibition, at one concentration (the size of the read-out at that concentration, not a potency): 29.9%
Compound 3: the middle estimate sits 24.9 percentage points below what was measured; measured number outside the range, above it.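

On the saturated ring carbon two ring bonds from the ring nitrogen, amino in place of hydrogen proves not to be a silent change: compound 2, with plain pyrrolidin-1-yl, is reported as "not active" in this assay, whereas compound 3, with 3-aminopyrrolidin-1-yl, gives 29.9%. Among these compounds, the only step that can be read in numbers is a number 27.8 percentage points higher from compound 1 to compound 3 (beyond the scatter), which shows that inhibition can rise off the floor when 2-(3-aminopyrrolidin-1-yl)ethyl stands in place of 1-ethylpiperidin-4-yl. Nothing in the data shown accounts for this rise.

With no number for compound 2, the size of the amino step itself cannot be stated, and a reading at one concentration does not give the potency of compound 3. As far as these compounds go, what a hydroxyl or a dimethylamino group would give on that same ring carbon remains open, as does the outcome for the mirror-image form of the 3-aminopyrrolidin-1-yl group.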